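Compound 3: a ring nitrogen enters the acid-bearing end

A few compounds are considered here, and "the series" means these few. Any claim that something is new, unique, unknown or untested is made for them only; others in the source may bear on it.

Measured compounds:
- compound 1, `CC(C)c1onc(-c2c(Cl)cccc2Cl)c1COc1ccc(Cn2ccc3ccc(C(=O)O)cc32)cc1`, 42%
- compound 2, `CC(C)c1onc(-c2c(Cl)cccc2Cl)c1COc1ccc(-c2ccc3sc(C(=O)O)cc3c2)cc1`, 91%

Of the compounds shown here, two have been tested in a functional assay on CV-1 cells for agonist activity at Bile acid receptor (Homo sapiens), read by a luciferase reporter; on this read-out lower numbers stand for smaller maximal responses and higher numbers for larger maximal responses. Compound 1, `CC(C)c1onc(-c2c(Cl)cccc2Cl)c1COc1ccc(Cn2ccc3ccc(C(=O)O)cc32)cc1`, reaches 42%. Compound 2, `CC(C)c1onc(-c2c(Cl)cccc2Cl)c1COc1ccc(-c2ccc3sc(C(=O)O)cc3c2)cc1`, reaches 91%, the higher of the two numbers; the gap to compound 1 is well beyond the usual scatter, so compound 2 stands as the larger response of the pair. For the measured compounds named here, the two share the isoxazole-bearing head and the ether-linked phenyl ring, and differ in the whole acid-bearing end, so no single-point step joins them.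

Compound 3, `CC(C)c1onc(-c2c(Cl)cccc2Cl)c1COc1ccc(-c2ccc3sc(C(=O)O)cc3n2)cc1`, departs from compound 2 in one place: a group of 12 heavy atoms (8 carbon, 1 nitrogen, 2 oxygen, 1 sulfur; one five-membered aromatic ring with 1 hetero atom, one six-membered aromatic ring with 1 hetero atom) in place of a group of 12 heavy atoms (9 carbon, 2 oxygen, 1 sulfur; one five-membered aromatic ring with 1 hetero atom, one six-membered aromatic ring of carbon only), on an aromatic carbon. The change keeps the acid, the ring count and the shape of the bicycle, and only exchanges one ring carbon for a nitrogen in the six-membered ring. Going by the values given here, no measured pair shows the effect of such an exchange here.

With nothing against it in the data, compound 3 is expected to stay close to compound 2, with a step of a number 11 percentage points lower from compound 2 to compound 3 (beyond the scatter) that may lie within the scatter or be a modest drop. The estimate for compound 3 in this assay is 80%, ranging from 55% to 100%.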

Compound 3, largest response reached (Emax), in percent of the reference or control that the assay uses: 82%
Beside the measured number, compound 3's estimate is 2 percentage points below it; the measured number falls inside the stated range.
By their numbers in this assay, from the lowest: compound 1; then compounds 3 and 2 (each within the scatter of the next).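

In this assay, for the compounds shown here, putting a ring nitrogen into the six-membered ring of the 2-carboxy-1-benzothiophen-5-yl group gives a number 9 percentage points lower from compound 2 to compound 3 (within the scatter), the first single-place comparison, since compound 1 and compound 2 differ in the whole acid-bearing end. At this position, on an aromatic carbon para to a large group, the exchange of one ring carbon for a nitrogen therefore leaves the maximal response of compound 3 indistinguishable from that of compound 2, and the large response seen with this acid-bearing end survives the change. No measurement is available here that would explain this outcome.

The compounds shown leave open whether a ring nitrogen elsewhere in this six-membered ring would be tolerated in the same way, or whether a second ring nitrogen could be added to the one in compound 3. They also leave open whether the response would hold if the carboxylic acid on this end gave way to a primary amide or a tetrazole, or if an oxygen took the place of the ring sulfur.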